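The compounds below may be only part of what the source reports. "The series", "measured", "known", "first", "only" and "open" are said of these compounds alone.

In a functional assay on A549 cells (Homo sapiens) for antiproliferative activity, read by MTT assay, with a stated time of 72 h (a higher number here means a weaker inhibitor, a lower number a stronger inhibitor), compound 3 `O=C1COc2ccc(-c3cnc4ccccc4c3)cc2N1` gives > 40000 nM, which is a limit and not a number. Compound 3 carries only hydrogen on its amide-type nitrogen. The change to compound 4 `O=C1COc2ccc(-c3cnc4ccccc4c3)cc2N1c1ccc(Cl)cc1` is 4-chlorophenyl in place of hydrogen on an amide-type nitrogen in a ring, with 4-chlorophenyl in place of that hydrogen.

Two measured compounds carry other groups at this nitrogen. Compound 2 `Cc1ccc(N2C(=O)COc3ccc(-c4cnc5ccccc5c4)cc32)cc1`, with 4-methylphenyl there, gives > 40000 nM, also a limit. Compound 1 `O=C1COc2ccc(-c3cnc4ccccc4c3)cc2N1C1CCCCC1`, with cyclohexyl there, gives > 40000 nM, again a limit.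

The closest comparison is a step that the two limits leave unreadable from compound 2 to compound 3, since 4-methylphenyl and 4-chlorophenyl are both substituted phenyl groups. The other relevant comparison is a step that the two limits leave unreadable from compound 1 to compound 3. Neither gives a size, so the guidance they offer is weak.

A step beyond the usual scatter is not expected for compound 4 because of the limit of > 40000 nM in this assay, at which 3 of the 3 values shown sit. The estimated size of a number no higher from compound 3 to compound 4 (the limit leaves the size open) is therefore small, with no clear direction. Compound 4 is expected to give about 40000 nM, with an estimated range from 12000 nM to 60000 nM.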

Compound 4, half-maximal inhibitory concentration: > 40000 nM
Compound 4 gave a limit, no number (the forecaster's own chance of this, stated with the estimate: 80%); the middle value sits exactly at the limit.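

Compound 4 gives > 40000 nM, a limit and not a number. Its steps to compound 1, compound 2 and compound 3 are all limit against limit and cannot be read. The compounds shown leave open whether any group on the amide-type nitrogen changes the result in this assay.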